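This account rests on a few compounds, and the source may have more. Where it says the series, first, only, none or still open, it means among the compounds named here.

In a functional assay (ileum) with Cavia porcellus as the target (on this read-out lower numbers stand for stronger inhibition and higher numbers for weaker inhibition), compound 1 `CC(=O)CCCCCC/N=C/N1CCC(C(c2ccccc2)c2ccccc2)CC1` gives 2.2 ug/mL and compound 2 `CC(O)CCCCCC/N=C/N1CCC(C(c2ccccc2)c2ccccc2)CC1` gives 1.7 ug/mL. Among the measured compounds shown here, these are the only two numbers so far, and they lie within the usual scatter of each other, so compound 2 stands level with compound 1. Compound 3 `OCCCCCCCC/N=C/N1CCC(C(c2ccccc2)c2ccccc2)CC1` has the same atoms as compound 2, joined differently: 2-hydroxyethyl in place of 1-hydroxyethyl on a saturated chain carbon, six bonds along the chain from a double-bonded nitrogen. Put simply, 2-hydroxyethyl takes the place of 1-hydroxyethyl on a saturated chain carbon, six bonds along the chain from a double-bonded nitrogen. For the measured compounds named here, the one measured step that bears on this change sits at that same place: a 1.3-fold lower number from compound 1 to compound 2 (0.11 log units; within the scatter). Going by the values given here, no measured compound yet carries 2-hydroxyethyl, so this is thin evidence, and no step beyond the scatter is expected in this assay. The expected step is a 1.1-fold higher number from compound 2 to compound 3 (0.02 log units; within the scatter). For compound 3 the estimated value is 1.8 ug/mL, with an expected range from 0.8 ug/mL to 4 ug/mL.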

Compound 3, half-maximal inhibitory concentration: 0.29 ug/mL
Beside the measured number, compound 3's estimate is 6.2-fold (0.79 log units) above it; measured number below the stated range.
By their numbers in this assay, from the lowest: compound 3; then compounds 2 and 1 (each within the scatter of the next).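

In this assay, 2-hydroxyethyl in place of 1-hydroxyethyl keeps the same atoms yet gives a 5.9-fold lower number from compound 2 to compound 3 (0.77 log units; beyond the scatter), so at this place, on a saturated chain carbon, six bonds along the chain from a double-bonded nitrogen, how the atoms are joined counts and not only which atoms are there. The change from acetyl to 2-hydroxyethyl gives a 7.6-fold lower number from compound 1 to compound 3 (0.88 log units; beyond the scatter), which shows a sensitivity at this place that the earlier step from acetyl to 1-hydroxyethyl, within the scatter, did not reveal. Nothing available explains this difference.

Still open, from the compounds shown here alone, is whether the hydroxyl itself is needed, which an amine or a carboxylic acid in place of it could test. Also open, going by these compounds, is how a longer chain carrying the same hydroxyl would compare with compound 3.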